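Removing the Amine Side Chain from an Acylsulfonamide Triazine

The source may report more compounds than this note shows. Statements on the series, on what has been measured and on what is new or still open speak of the compounds shown alone.

Measured so far:
compound 1 `CC(C)NCCS(=O)(=O)NC(=O)c1ccc(Nc2nc(NC3(c4ccc(Cl)cc4)CC3)nc(OCC(F)(F)F)n2)cc1`: 45 nm/s
compound 2 `CC(C)(C)CNCCS(=O)(=O)NC(=O)c1ccc(Nc2nc(NC3(c4ccc(Cl)cc4)CC3)nc(OCC(F)(F)F)n2)cc1`: 651 nm/s

In a physicochemical assay for permeability, using PAMPA, at pH 7.4 (a higher number here means that the compound crosses the layer faster, a lower number that the compound crosses the layer more slowly), compound 2 gives the higher of the two numbers; its nearest neighbour is compound 1, and the step of a 14-fold higher number from compound 1 to compound 2 (1.16 log units; beyond the scatter) separates them. Compound 3 `CS(=O)(=O)NC(=O)c1ccc(Nc2nc(NC3(c4ccc(Cl)cc4)CC3)nc(OCC(F)(F)F)n2)cc1` has not been measured in this assay. It differs from compound 2 by hydrogen in place of (neopentylamino)methyl on a saturated chain carbon bound to a sulfonyl sulfur, so the neopentylamine that distinguishes compound 2 from compound 1 is lost altogether and a methylsulfonyl group remains.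

For the measured compounds named here, only one step bears on this change, a 14-fold higher number from compound 1 to compound 2 (1.16 log units; beyond the scatter), and it shows that the group on the amine nitrogen moves the number strongly. Going by the values given here, no measured pair removes the whole chain, so the direction is uncertain; the estimate for compound 3 is 120 nm/s, spanning 20 nm/s to 700 nm/s, which is expected to mean a step of a 5.4-fold lower number from compound 2 to compound 3 (0.73 log units; beyond the scatter).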

Compound 3, apparent permeability: 11 nm/s
For compound 3 the middle estimate is 11-fold (1.04 log units) above the measured one; measured number outside the range, below it.
By their numbers in this assay, from the lowest: compound 3; then compound 1; then compound 2.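

In this assay there is a 59-fold lower number from compound 2 to compound 3 (1.77 log units; beyond the scatter) when the 2-(neopentylamino)ethyl group gives way to methyl, and the same kind of replacement on the isopropyl partner gives a 4.1-fold lower number from compound 1 to compound 3 (0.61 log units; beyond the scatter) as its smaller counterpart. The group on the sulfonyl sulfur therefore matters in both pairs: with methyl there, the number lies under those of both amine-bearing compounds, and the size of the fall differs with the group on the amine nitrogen. Nothing measured alongside these numbers accounts for the falls.

On these data alone, whether a plain alkyl chain with no amine nitrogen would keep the higher numbers remains open, so the contributions of the nitrogen and of the carbon atoms cannot be separated. It is also unknown how a carboxylic acid or a cyclic amine on this chain would behave.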